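This account rests on a few compounds, and the source may have more. Where it says the series, first, only, none or still open, it means among the compounds named here.

In an ADME assay on MRC5 cells (Homo sapiens) for inhibition, with a stated time of 72 h (on this read-out higher numbers stand for an effect only at larger amounts of compound and lower numbers for an effect already at smaller amounts), compound 1 `COc1ccccc1C(=O)Nc1c[nH]nc1C(=O)N[C@H]1CC[C@H](OC)CC1` gives 1500 nM. In this assay compound 2 `COc1cccc(OC)c1C(=O)Nc1c[nH]nc1C(=O)N[C@H]1CC[C@H](OC)CC1` gives 31000 nM. The single step measured so far is a 21-fold higher number from compound 1 to compound 2 (1.32 log units; beyond the scatter), so on the numbers shown compound 2 stands highest of the two. Compound 3 `COc1cccc(OC)c1C(=O)Nc1c[nH]nc1C(=O)NC1CCCCC1` differs from compound 2 in another place: hydrogen in place of methoxy on a saturated ring carbon. Going by the values given here, no measured step touches that saturated ring, and nothing here points in either direction. The step is therefore expected to stay within the scatter, no change at the digits printed from compound 2 to compound 3 (within the scatter). Compound 3 is estimated at 31000 nM, most likely between 10000 nM and 90000 nM.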

Compound 3, half-maximal effective concentration: 35000 nM
Estimate against measurement, compound 3: 1.1-fold (0.05 log units) below; measured number inside the range.
By their numbers in this assay, from the lowest: compound 1; then compounds 2 and 3 (each within the scatter of the next).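

Putting hydrogen in place of methoxy on the saturated ring carbon gives a 1.1-fold higher number from compound 2 to compound 3 (0.05 log units; within the scatter) in this assay so the 4-methoxycyclohexyl and cyclohexyl compounds cannot be told apart on this read-out. This holds with both methoxy groups present on the aromatic ring, and only for that pair. Nothing available explains this result.

On these data alone, whether an amine, a carboxylic acid or a longer chain on this ring carbon would read the same stays open. So does whether the same swap would be as quiet on compound 1, whose aromatic ring carries one methoxy fewer.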